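Replacing a chlorophenyl with a phenoxy group

The source may report more compounds than this note shows. Statements on the series, on what has been measured and on what is new or still open speak of the compounds shown alone.

Compound 1: `O=C(CCCCCCc1ccc(F)cc1)N1CCCC1` gives 8000 nM in an assay on HEK293 cells for inhibition of N-acylethanolamine-hydrolyzing acid amidase (Rattus norvegicus), read by LC-MS, with a stated time of 30 min; a higher number here means a weaker inhibitor, a lower number a stronger inhibitor.
Compound 2: `O=C(CCc1ccc(-c2ccccc2Cl)cc1)N1CCCC1` reaches only > 100000 nM in this assay.

Compound 2 does not yield a number in this assay; it shows only a limit, which is where the limit of > 100000 nM in this assay, at which 1 of the 2 values shown sits, places it. Compound 1, with its longer chain and a fluorine on the aromatic ring, gives a measured value, so of the two measured compounds only compound 1 gives a real potency reading.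

The next compound, compound 3, has the structure `O=C(CCc1ccc(Oc2ccccc2)cc1)N1CCCC1`. It differs from compound 2 in one place: phenoxy in place of 2-chlorophenyl on an aromatic carbon on an aromatic carbon, para to a group of 9 heavy atoms, as the structures show.

Within the data shown here, since compound 2 sits at a limit, no measured step frames the expected size of this change. The phenoxy group keeps the same number of heavy atoms and adds one hydrogen-bond acceptor, and a move away from the limit seems plausible, though any gain is uncertain. Compound 3 is therefore expected to show 60000 nM (range 8000 nM to 200000 nM), an expected step of an at least 1.6-fold lower number from compound 2 to compound 3 (0.22 log units; that floor lies within the scatter), with a fair chance that it again reports only a limit.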

Compound 3, half-maximal inhibitory concentration: > 100000 nM
Compound 3 gave a limit, no number; the forecaster's own chance of this, stated with the estimate: 45%; middle value at least 1.6-fold (0.22 log units) from the limit.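

Replacing 2-chlorophenyl with phenoxy gives no step that can be read between compound 2 and compound 3, since each reports a limit and not a number: the limit of > 100000 nM in this assay, at which 2 of the 3 values shown sit.

The compounds shown leave open whether phenoxy in place of 2-chlorophenyl changes inhibitor strength at all in this assay.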